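The source may report more compounds than this note shows. Statements on the series, on what has been measured and on what is new or still open speak of the compounds shown alone.

The measured compounds are compound 1 `O=C(CCl)Nc1ccc(C(=O)/C=C/c2ccc(Cl)cc2)cc1` with 4960 nM in a functional assay on MGC-803 cells (Homo sapiens) for cytotoxicity, read by MTT assay, with a stated time of 72 h (on this read-out lower numbers stand for stronger inhibition and higher numbers for weaker inhibition), and compound 2 `O=C(CSC(=S)N[C@H]1CCOC1=O)Nc1ccc(C(=O)/C=C/c2ccc(Cl)cc2)cc1` with 6900 nM in this assay.

Compound 2 holds the higher of the two numbers in this assay; its nearest neighbour is compound 1, and the gap a 1.4-fold higher number from compound 1 to compound 2 (0.14 log units; within the scatter) lies within the scatter, so the two cannot be told apart. Compound 3 `O=C(CSC(=S)N[C@H]1CCOC1=O)Nc1ccc(C(=O)/C=C/c2ccc([N+](=O)[O-])cc2)cc1` differs from compound 2 by nitro in place of chloro on an aromatic carbon. Going by the values given here, the only measured step, a 1.4-fold higher number from compound 1 to compound 2 (0.14 log units; within the scatter), concerns another place, the saturated chain carbon bound to a carbonyl carbon, and says nothing about a change on the aromatic ring. Among the compounds with values here, no measured step bears on the exchange of chloro for nitro, so nothing in the data points to a step beyond the scatter in either direction in this assay. Compound 3 is therefore expected to give about 7000 nM, with a range from 2500 nM to 20000 nM. The expected step is a 1.0-fold higher number from compound 2 to compound 3 (0.01 log units; within the scatter), judged to stay within the scatter.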

Compound 3, half-maximal inhibitory concentration: 29400 nM
The estimate for compound 3 lay 4.2-fold (0.62 log units) below the measured number, and the stated range ends below it.
By their numbers in this assay, from the lowest: compounds 1 and 2 (each within the scatter of the next); then compound 3.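

Nitro in place of chloro on an aromatic carbon gives a 4.3-fold higher number from compound 2 to compound 3 (0.63 log units; beyond the scatter) in this assay and so shows that this position, on the ring para to a large group, responds to the exchange, with the nitro compound giving the weaker inhibition. The earlier step of a 1.4-fold higher number from compound 1 to compound 2 (0.14 log units; within the scatter) at the saturated chain carbon stayed within the scatter and gave no such reading for any place in the molecule. No measurement accompanies these compounds that would account for the step.

Going by these compounds, it remains open whether an amine, a methoxy group or a fluorine atom at this ring position would stay close to chloro or follow nitro. On these data alone, it is also open whether the 4-chlorophenyl to 4-nitrophenyl exchange would give a similar step with the chloroacetyl chain of compound 1 in place.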